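The source may hold more compounds than are shown below. What is called first, only, known or untested is meant among the compounds shown, and "the series" means these compounds.

In a functional assay on the whole organism (stomach) with Rattus norvegicus as the target (a lower number here means that less compound is needed, a higher number that more compound is needed for the effect), compound 1 (`CCCC[C@](C)(OC)[C@@H](O)/C=C/C1[C@H](O)CC(=O)[C@@H]1C/C=C\CCCC(=O)OC`) gives 1.5 mg/kg and compound 2 (`CCCC[C@](C)(OC)[C@H](O)/C=C/C1[C@H](O)CC(=O)[C@@H]1C/C=C\CCCC(=O)OC`) gives 0.5 mg/kg. Compound 2 therefore holds the lower of the two numbers, with a gap beyond the scatter. Compound 3 (`CCCC[C@@](C)(OC)[C@H](O)/C=C/C1[C@H](O)CC(=O)[C@@H]1C/C=C\CCCC(=O)OC`) has not yet been measured. Its relation to compound 2 is: the two compounds have the same atoms and bonds; at least one stereo element is drawn with a configuration in one of them and without one in the other: 1 of 7 stereo elements differ; a stereocentre at a saturated chain carbon is drawn S in compound 2 and R in compound 3. Among the compounds with values here, the only measured step that bears on this is a 3.0-fold lower number from compound 1 to compound 2 (0.48 log units; beyond the scatter), which is also a change of configuration alone at a saturated chain carbon. That carbon is drawn R in compound 2, whereas the stereocentre changing now is drawn S there, so a different centre is involved and the earlier step serves only as a guide to size. Within the data shown here, on that guide, a modest step towards a higher number in this assay is expected, starting from the lower of the two values so far. A step within the scatter cannot be ruled out. The expected step is a 2.4-fold higher number from compound 2 to compound 3 (0.38 log units; beyond the scatter). For compound 3 the estimated value is 1.2 mg/kg, with an expected range of 0.3 mg/kg to 4 mg/kg.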

Compound 3, dose for 50% inhibition: 0.0072 mg/kg
The estimate for compound 3 lay 170-fold (2.22 log units) above the measured number; measured number outside the range, below it.
By their numbers in this assay, from the lowest: compound 3; then compound 2; then compound 1.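

In this assay, inverting this one saturated chain carbon from S to R gives a 69-fold lower number from compound 2 to compound 3 (1.84 log units; beyond the scatter), so the configuration at this centre has a large effect on the number, and the direction favours R in the compounds shown. That step far exceeds the change at the other stereocentre, a 3.0-fold lower number from compound 1 to compound 2 (0.48 log units; beyond the scatter), so the two saturated chain centres do not carry equal weight here, and the modest earlier step did not indicate the size possible at this position. Across both changes the series spans a 210-fold lower number from compound 1 to compound 3 (2.32 log units; beyond the scatter), but two stereo elements differ in that pair, so this step cannot be assigned to either centre alone.

As far as these compounds go, the fourth combination of configurations at these two centres stays open, as does whether the two effects would combine in the same way there. Also open, from the compounds shown here alone, is whether the preference for R at this carbon would persist with a carboxylic acid in place of the methyl ester, or with an ethoxy group in place of the methoxy group.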